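The source may hold more compounds than are shown below. What is called first, only, known or untested is meant among the compounds shown, and "the series" means these compounds.

Measured compounds:
Compound 1 `O=C(NO)c1ccc(NCc2nc(-c3cccc(Cl)c3)nn2-c2ccccc2)cc1` gives 61.2% in an assay on Sf9 cells for inhibition of protein deacetylase HDAC6 (Homo sapiens), read by fluorescence, with a stated time of 40 min, tested at 100 nM; a lower number here means less inhibition, a higher number more inhibition at the concentration tested (going by the name of the read-out).
Compound 2 `Nc1ccccc1NC(=O)c1ccc(NCc2nc(-c3ccccc3)nn2-c2ccccc2)cc1` gives 5% in this assay.
Compound 3 `O=C(NO)c1ccc(NCc2nc(-c3ccccc3)nn2-c2ccc(F)cc2)cc1` gives 67.6% in this assay.

Among these three, compound 3 stands highest; its nearest neighbour is compound 1, whose number lies within the scatter of it, while compound 2 lies far below, beyond the scatter. Compound 4 `Cc1cc(C)cc(-n2nc(-c3ccccc3)nc2CNc2ccc(C(=O)NO)cc2)c1` has not yet been measured in this assay. It differs from compound 3 in one place: 3,5-dimethylphenyl in place of 4-fluorophenyl on an aromatic nitrogen. Among the measured compounds shown here, no step between measured compounds isolates this kind of change, so the data give no direction for it. Compound 4 is therefore expected to show a step of a number 4.6 percentage points lower from compound 3 to compound 4 (within the scatter), not beyond the scatter. Compound 4 is estimated at 63%, in the range 45% to 80%.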

Compound 4, a percentage reported as inhibition, at one concentration (the size of the read-out at that concentration, not a potency): 49.8%
Compound 4: middle estimate off by 13.2 percentage points, on the high side; the measured number falls inside the stated range.
By their numbers in this assay, from the lowest: compound 2; then compound 4; then compounds 1 and 3 (each within the scatter of the next).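

Placing 3,5-dimethylphenyl in place of 4-fluorophenyl on the aromatic nitrogen gives a number 17.8 percentage points lower from compound 3 to compound 4 (beyond the scatter) in this assay, the first sign that this position responds to the group it carries. The two groups match in counted features, each being one six-membered aromatic ring of carbon only with no hydrogen-bond donors or acceptors, yet they are not interchangeable here. Nothing measured here explains the fall.

A single step cannot separate the two methyl groups from the loss of fluorine. Going by these compounds, how a methoxy-bearing phenyl or a saturated amine such as piperidine would behave at this position remains open.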